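This account rests on a few compounds, and the source may have more. Where it says the series, first, only, none or still open, it means among the compounds named here.

Compound 1 `COc1cccc(C(=O)Nc2ccc(Cl)cc2CN2C(=O)c3ccccc3C2=O)c1`: in an assay on CHO cells for positive allosteric modulation of metabotropic glutamate receptor 5 (Homo sapiens), read by FLIPR (on this read-out lower numbers stand for an effect already at smaller amounts and higher numbers for an effect only at larger amounts of compound), compound 1 gives 1500 nM.
Compound 2 `O=C(Nc1ccc(Cl)cc1CN1C(=O)c2ccccc2C1=O)c1ccccc1[N+](=O)[O-]`: compound 2 gives 5700 nM.
Compound 3 `O=C(Nc1ccc(Cl)cc1CN1C(=O)c2ccccc2C1=O)c1ccco1`: compound 3 gives 2300 nM.

Compound 3 stands second highest of the three numbers; it lies within the scatter of compound 1 (a 1.5-fold higher number from compound 1 to compound 3 (0.19 log units; within the scatter)) but beyond that of compound 2 (a 2.5-fold lower number from compound 2 to compound 3 (0.39 log units; beyond the scatter)). Compound 4 `O=C(Nc1ccc(Cl)cc1CN1C(=O)c2ccccc2C1=O)c1ccccc1C(F)(F)F` differs from it in one place: 2-(trifluoromethyl)phenyl in place of furan-2-yl on a carbonyl carbon. The step that bears most on this change is the modest one between a 2-nitrophenyl and furan-2-yl, a 2.5-fold lower number from compound 2 to compound 3 (0.39 log units; beyond the scatter); the step of a 3.8-fold higher number from compound 1 to compound 2 (0.58 log units; beyond the scatter) points the same way for the 2-nitrophenyl. Because of a 2.5-fold lower number from compound 2 to compound 3 (0.39 log units; beyond the scatter) a modest rise is expected for compound 4, a 2.0-fold higher number from compound 3 to compound 4 (0.29 log units; within the scatter). Compound 4 is therefore estimated at 4500 nM, within 1800 nM to 11000 nM.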

Compound 4, half-maximal effective concentration: 5700 nM
Compound 4: the middle estimate sits 1.3-fold (0.10 log units) below what was measured; the range from low to high includes it.
By their numbers in this assay, from the lowest: compounds 1 and 3 (each within the scatter of the next); then compounds 2 and 4 (each within the scatter of the next).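

In this assay, trifluoromethyl in place of nitro on an aromatic carbon leaves the number unmoved, with no change at the digits printed from compound 2 to compound 4 (within the scatter), so these two groups cannot be told apart here. Compound 4 also stands clear of both other groups on the carbonyl carbon, with a 2.5-fold higher number from compound 3 to compound 4 (0.39 log units; beyond the scatter) and a 3.8-fold higher number from compound 1 to compound 4 (0.58 log units; beyond the scatter), which puts compounds 2 and 4 together at the higher numbers among these four compounds. No measurement shown offers an explanation for this match.

On these data alone, it remains open whether an amine or a carboxylic acid in place of the trifluoromethyl would keep this number or shift it.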